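Working notes on a short aryl ether series, compound 4 pending

A few compounds are considered here, and "the series" means these few. Any claim that something is new, unique, unknown or untested is made for them only; others in the source may bear on it.

Measured so far in an assay on cells for inhibition of Voltage-dependent T-type calcium channel subunit alpha-1H (Homo sapiens), read by FLIPR and calcium flux, with stated times of 600 s and 300 s; on this read-out lower numbers stand for stronger inhibition and higher numbers for weaker inhibition:
compound 1 `CN(Cc1ccc(OCCCN)cc1)c1nc2ccc(Oc3ccc(F)cc3)cc2s1` gives 492000 nM
compound 2 `CN(Cc1ccc(OCCCNC(=N)N)cc1)c1nc2ccc(Oc3ccc(C(F)(F)F)cc3)cc2s1` gives 212000 nM
compound 3 `CN(Cc1ccc(OCCCNC(=N)N)cc1)c1nc2ccc(Oc3cccc(C(F)(F)F)c3)cc2s1` gives 771000 nM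

Compound 1 holds the second highest of the three numbers in this assay. Its nearest neighbour is compound 3, whose number lies within the scatter of that of compound 1; compound 2 stands furthest off, with a number beyond the scatter below that of compound 1. For the measured compounds named here, the only step between compounds differing in one place is a 3.6-fold higher number from compound 2 to compound 3 (0.56 log units; beyond the scatter), a modest shift.

The step to be followed goes from compound 1 to compound 4 `CN(Cc1ccc(OCCCN)cc1)c1nc2ccc(Oc3ccc(O)cc3)cc2s1`, with this change: hydroxy in place of fluoro on an aromatic carbon. Going by the values given here, the one measured step concerns the position of trifluoromethyl on the aryl ether ring and not an exchange of fluoro for hydroxy, so no measured step bears on this change, and the three measured compounds give no direct guide. With nothing to build on, the working expectation is a number for compound 4 close to that of compound 1, with no shift beyond the scatter, so that a 1.2-fold higher number from compound 1 to compound 4 (0.09 log units; within the scatter) is expected to be small. Compound 4 is therefore estimated at 600000 nM, within a range from 250000 nM to 1500000 nM.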

Compound 4, half-maximal inhibitory concentration: 165000 nM
Compound 4: middle estimate off by 3.6-fold (0.56 log units), on the high side; measured number outside the range, below it.
By their numbers in this assay, from the lowest: compounds 4 and 2 (each within the scatter of the next); then compounds 1 and 3 (each within the scatter of the next).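

In this assay hydroxy in place of fluoro on an aromatic carbon, para to a large group, gives a 3.0-fold lower number from compound 1 to compound 4 (0.47 log units; beyond the scatter) and so shows that the number responds to which group stands at this place. The earlier step on the aryl ether ring, a 3.6-fold higher number from compound 2 to compound 3 (0.56 log units; beyond the scatter) with the move to 3-(trifluoromethyl)phenyl, concerned only where one group sat. Here the place stays the same and the group is exchanged, with the rest of compound 1 unchanged. The change adds a hydrogen-bond donor and a hydrogen-bond acceptor by count, but nothing available explains the step, so that count stands only as a description of the change.

Open, going by these compounds, is whether the step belongs to hydroxy in particular or would also appear with methoxy, an amine or a carboxylic acid at the same place, and hydrogen or chloro in place of fluoro would show how much fluoro itself contributes. Also open, on these data alone, is whether the same exchange acts alike with the guanidine-bearing chain of compound 2, or with a longer chain in place of the aminopropoxy chain of compound 1.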